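The source may report more compounds than this note shows. Statements on the series, on what has been measured and on what is new or still open speak of the compounds shown alone.

Measured so far in an ADME assay on microsomes from liver (Rattus norvegicus) for metabolic stability, with a stated time of 10 min; a higher number here means that more of the compound is left, a lower number that less of the compound is left:

- compound 1, `COc1cc(OCc2cccc(COc3ccccc3)c2)c2cc(-c3cn4nc(OC)sc4n3)oc2c1`: 64%
- compound 2, `COc1cc(OCc2cccc(C#N)c2)c2cc(-c3cn4nc(OC)sc4n3)oc2c1`: "not determined" (no result reported)

Compound 1 carries a phenoxymethyl group and keeps a good share of its material after the incubation, as compound 1 shows with 64% in this assay. Compound 2, which carries a cyano group in the same position of the benzyl ether, has no number of its own in this assay: for compound 2 the result is "not determined" (no result reported), so compound 2 stands nowhere on the scale shown, and no step between two measured compounds is available.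

Compound 3, `COc1cc(OCc2cccc(Oc3ccccc3)c2)c2cc(-c3cn4nc(OC)sc4n3)oc2c1`, comes from compound 2 by one change: phenoxy in place of cyano on an aromatic carbon. Compound 3 thus ends up close in build to compound 1, differing from it only in how the outer phenyl ring is joined. For the measured compounds named here, with nothing measured for compound 2, no direction for the step in this assay can be read from data; the expectation rests on compound 1 alone, whose 64% is the only anchor. Compound 3 is therefore expected to land near that anchor, estimated at 55%, within a range of 25% to 85%.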

Compound 3, percent of the compound remaining: 42%
The estimate for compound 3 lay 13 percentage points above the measured number; the measured number falls inside the stated range.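

Phenoxy in place of phenoxymethyl on an aromatic carbon gives a number 22 percentage points lower from compound 1 to compound 3 (beyond the scatter) in this assay, a modest step that lies beyond the usual scatter. For the compounds shown here, this is the first pair of compounds here that differ in one place and both carry a number, and it shows that this position responds to how the outer phenyl ring is joined, even though the ring itself stays. The change from the cyano group of compound 2 to phenoxy cannot be read, since compound 2 has no number, and nothing at hand gives a reason for the step from phenoxymethyl to phenoxy.

The compounds shown compare only two ways of joining an unsubstituted phenyl ring, so it stays open whether a longer chain such as phenoxyethyl would continue the same trend or break it. From the compounds shown here alone, it also stays open how an amine or a carboxylic acid in this place, or a chlorine on the outer phenyl ring, would move the share of compound left after the incubation.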